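From compound 3 to compound 4: a longer chain

The source may hold more compounds than are shown below. What is called first, only, known or untested is meant among the compounds shown, and "the series" means these compounds.

Of the compounds shown here, three sharing one core have been measured. In a functional assay on brain (Rattus norvegicus, strain Wistar) for inhibition (on this read-out lower numbers stand for stronger inhibition and higher numbers for weaker inhibition), compound 1 (`CCCCOc1ccc(-c2c(C)[nH]c(=O)n2C2CCCCC2)cc1`) gives 13900 nM while compound 2 (`Cc1[nH]c(=O)n(C2CCCCC2)c1-c1ccc(OC(C)C)cc1`) gives 13000 nM and compound 3 (`Cc1[nH]c(=O)n(C2CCCCC2)c1-c1ccc(OCCC(C)C)cc1`) gives 7200 nM on the same scale. Compound 3 therefore stands within the scatter of both others, as the steps (a 1.9-fold lower number from compound 1 to compound 3 (0.29 log units; within the scatter)) and (a 1.8-fold lower number from compound 2 to compound 3 (0.26 log units; within the scatter)) show. Compound 4 (`CCCCCCCOc1ccc(-c2c(C)[nH]c(=O)n2C2CCCCC2)cc1`) is still unmeasured. It carries pentyl in place of isopropyl on a saturated chain carbon, two bonds along the chain from an oxygen on an aromatic ring, which also reads isopentyloxy to heptyloxy (pentyl in place of isopropyl on a saturated chain carbon, two bonds along the chain from an oxygen on an aromatic ring). The closest evidence is the other change on that oxygen (a 1.1-fold lower number from compound 1 to compound 2 (0.03 log units; within the scatter)), and like the two steps above it stays within the scatter. Within the data shown here, no heptyl compound has been measured, so this is an extrapolation. In this assay the expected step is a 1.1-fold higher number from compound 3 to compound 4 (0.05 log units; within the scatter) and thus none beyond the scatter. Compound 4 is estimated to give 8000 nM with an expected range from 3500 nM to 18000 nM in this measurement.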

Compound 4, half-maximal inhibitory concentration: 11600 nM
Estimate against measurement, compound 4: 1.5-fold (0.16 log units) below, within the range that was stated.
By their numbers in this assay, from the lowest: compounds 3, 4, 2 and 1 (each within the scatter of the next).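

In this assay, heptyloxy on the aromatic ring gives no step beyond the scatter against any of the shorter or branched ethers (a 1.6-fold higher number from compound 3 to compound 4 (0.21 log units; within the scatter); a 1.1-fold lower number from compound 2 to compound 4 (0.05 log units; within the scatter); a 1.2-fold lower number from compound 1 to compound 4 (0.08 log units; within the scatter)). At this position, pentyl in place of isopropyl on the saturated chain carbon therefore leaves the number within the scatter, and so a straight chain as long as heptyl separates itself from none of compounds 1, 2 and 3 on this read-out. No available finding bears on this result or offers an account of it.

What the compounds leave open is whether any change on this oxygen can move the number beyond the scatter. Among the groups not represented here are a chain carrying an amine and a chain carrying a carboxylic acid.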